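Benzylsulfanyl variation on a triazole series: antiproliferative read-out

A few compounds are considered here, and "the series" means these few. Any claim that something is new, unique, unknown or untested is made for them only; others in the source may bear on it.

Measured compounds:
compound 1 `Sc1nnc(-c2ccc3c(c2)OCCO3)n1-c1ccccc1`: 51900 nM
compound 2 `O=[N+]([O-])c1ccccc1CSc1nnc(-c2ccc3c(c2)OCCO3)n1-c1ccccc1`: 69800 nM

In a functional assay on HeLa cells (Homo sapiens) for antiproliferative activity, read by MTT assay, with a stated time of 24 h (on this read-out higher numbers stand for weaker inhibition and lower numbers for stronger inhibition), compound 1 gives 51900 nM. Among the measured compounds shown here, its only measured neighbour is compound 2, and the step from compound 1 to compound 2 is a 1.3-fold higher number from compound 1 to compound 2 (0.13 log units; within the scatter), so the two compounds cannot be ranked against each other on this read-out.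

Compound 3 `Clc1cccc(CSc2nnc(-c3ccc4c(c3)OCCO4)n2-c2ccccc2)c1` is not yet measured. It differs from compound 1 by 3-chlorobenzyl in place of hydrogen on a sulfur. For the measured compounds named here, the one step that bears on this change is a 1.3-fold higher number from compound 1 to compound 2 (0.13 log units; within the scatter), which placed another benzyl group on the same sulfur without moving the number beyond the scatter. Going by the values given here, no other step exists, so the expectation for compound 3 rests on that single comparison alone.

On this basis compound 3 is expected to sit close to compound 1, with a step of about a 1.2-fold higher number from compound 1 to compound 3 (0.06 log units; within the scatter), which is expected to stay within the scatter. The estimate for compound 3 in this assay is 60000 nM, with a range of 25000 nM to 150000 nM.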

Compound 3, half-maximal inhibitory concentration: 15000 nM
Beside the measured number, compound 3's estimate is 4.0-fold (0.60 log units) above it, outside the stated range (below it).
By their numbers in this assay, from the lowest: compound 3; then compounds 1 and 2 (each within the scatter of the next).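

In this assay, the sulfur position responds to what is placed on it: 3-chlorobenzyl in place of hydrogen gives a 3.5-fold lower number from compound 1 to compound 3 (0.54 log units; beyond the scatter), whereas 2-nitrobenzyl on the same sulfur gives only a 1.3-fold higher number from compound 1 to compound 2 (0.13 log units; within the scatter). A benzyl group as such therefore does not fix the read-out, since exchanging 2-nitrophenyl for 3-chlorophenyl on the saturated chain carbon bound to the sulfur gives a 4.7-fold lower number from compound 2 to compound 3 (0.67 log units; beyond the scatter). Nothing available accounts for this difference between the two benzyl groups.

The compounds shown leave open whether the lower number of compound 3 belongs to the chlorine or to the benzyl group with that chlorine in its printed place. Unsubstituted benzyl, 4-chlorobenzyl and a longer chain such as 2-phenylethyl on the sulfur would each separate these readings.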